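Replacing 3-fluorophenyl with 4-bromophenyl in compound 2

The source may hold more compounds than are shown below. What is called first, only, known or untested is meant among the compounds shown, and "the series" means these compounds.

compound 1 `CN(C)C(=O)c1cc2cnc(Nc3ccc(N)cn3)nc2n1C1CCCC1`: -21.2%
compound 2 `CN(C)C(=O)c1cc2cnc(Nc3ccc(NC(=O)C4(C(=O)Nc5cccc(F)c5)CC4)cc3)nc2n1C1CCCC1`: 29.7%

In a functional assay on SiHa cells (Homo sapiens) for inhibition, read by CCK-8 assay, with a stated time of 72 h, tested at 1 uM (on this read-out higher numbers stand for more inhibition of growth at the one concentration tested and lower numbers for less inhibition of growth), compound 2 gives 29.7%, the higher of the two numbers. Compound 1 gives -21.2%, and the difference from compound 2 lies beyond the scatter. Compound 3 `CN(C)C(=O)c1cc2cnc(Nc3ccc(NC(=O)C4(C(=O)Nc5ccc(Br)cc5)CC4)cc3)nc2n1C1CCCC1` differs from compound 2 in one group: 4-bromophenyl in place of 3-fluorophenyl on an amide-type nitrogen. For the measured compounds named here, no measured pair shows such a swap. The expectation therefore stays close to compound 2 at 29.7%, with no step beyond the scatter expected in this assay. The estimated change is a number 0.3 percentage points higher from compound 2 to compound 3 (within the scatter). The expected value for compound 3 is 30%, with an estimated range of 8% to 55%.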

Compound 3, percent growth inhibition at one concentration: 23.2%
Estimate against measurement, compound 3: 6.8 percentage points above; the range from low to high includes it.
By their numbers in this assay, from the lowest: compound 1; then compounds 3 and 2 (each within the scatter of the next).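

In this assay, the step of a number 6.5 percentage points lower from compound 2 to compound 3 (within the scatter) shows that 4-bromophenyl can stand in for 3-fluorophenyl on the amide-type nitrogen with no real change in the read-out. For the compounds shown here, this is the first comparison here of two compounds that differ in one place, and it shows that this position accepts at least this one swap of halogen-bearing rings. No available measurement explains why the two groups read alike.

As far as these compounds go, whether an unsubstituted phenyl or a 4-methoxyphenyl would read the same remains open. So does whether a ring is needed at all on that nitrogen, as a simple ethyl chain there would show.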